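The compounds below may be only part of what the source reports. "The series", "measured", "known", "first", "only" and "open" are said of these compounds alone.

Working notes on the series. Compound 1 `Cc1cccc2[nH]c(-c3cc4ccccc4n3Cc3ccccc3)nc12` has no result in a functional assay on T47D cells (Homo sapiens) for antiproliferative activity, read by MTT assay, with a stated time of 48 h; a higher number here means a weaker inhibitor, a lower number a stronger inhibitor: for compound 1 the entry reads "not determined" (no result reported), so nothing was reported for it. Compound 2 `c1ccc(Cn2c(-c3nc4ccccc4[nH]3)cc3ccccc32)cc1` is the single measured member; in this assay compound 2 gives 21500 nM, the only number shown, so compound 2 stands alone, with nothing in the series to rank it against. Compound 3 `Brc1ccc2[nH]c(-c3cc4ccccc4n3Cc3ccccc3)nc2c1` is not yet measured. Compound 3 differs from compound 2 in one place: bromo in place of hydrogen on an aromatic carbon. Among the measured compounds shown here, no step between two measured compounds is available, so the effect of this kind of change in this assay cannot be read from the series itself; a step of modest size toward a stronger inhibitor is expected, though one that stays within the scatter is equally possible. Compound 3 is estimated at 12000 nM in this assay, with a range of 4000 nM to 40000 nM, which corresponds to an expected step of a 1.8-fold lower number from compound 2 to compound 3 (0.25 log units; within the scatter).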

Compound 3, half-maximal inhibitory concentration: 15500 nM
Beside the measured number, compound 3's estimate is 1.3-fold (0.11 log units) below it, within the range that was stated.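

In this assay, the series now gives its first readable step: bromo in place of hydrogen on this aromatic carbon, on the six-membered aromatic ring of carbon only that is part of a fused system, gives a 1.4-fold lower number from compound 2 to compound 3 (0.14 log units; within the scatter). This step lies within the scatter, so compound 2 and compound 3 cannot be told apart here, and this position accepts a single bromine atom without a measurable effect on the read-out. No available data bear on the reason for this result.

On these data alone, it remains open whether a different group on the same carbon, such as an amine or a carboxylic acid, would give a step beyond the scatter. A single step also leaves open whether bromo would behave in the same way on the other aromatic carbons of that ring.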